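A few compounds are considered here, and "the series" means these few. Any claim that something is new, unique, unknown or untested is made for them only; others in the source may bear on it.

Compound 1 `Oc1ccc(-c2cc3cccc(O)c3o2)c2cccnc12`: 14.5 10^-6 cm/s
Compound 2 `Oc1ccc2cc(-c3ccc4cccc(O)c4n3)oc2c1`: 15.8 10^-6 cm/s

Both values come from an ADME assay for permeability, using PAMPA, with a stated time of 10 h, tested at 100 ug/mL; a higher number here means that the compound crosses the layer faster, a lower number that the compound crosses the layer more slowly. Compound 2 stands level with compound 1 within the scatter, so neither can be ranked above the other on these numbers. Compound 3 `Oc1cc(O)c2cc(-c3ccc4cccc(O)c4n3)oc2c1` is the next to be read in this assay. It departs from compound 2 in one place: hydroxy in place of hydrogen on an aromatic carbon. This is hydroxy in place of hydrogen on an aromatic carbon, meta to a hydroxy group. For the measured compounds named here, the two measured compounds do not differ in one place only, so no measured step bears on this change, and the expectation rests on the structural change alone. A small move towards a lower number is expected, not clearly beyond the scatter. The expected step is a 1.8-fold lower number from compound 2 to compound 3 (0.24 log units; within the scatter). For compound 3 the estimated value is 9 10^-6 cm/s, with an expected range of 4 10^-6 cm/s to 17 10^-6 cm/s.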

Compound 3, apparent permeability: 13.3 10^-6 cm/s
The estimate for compound 3 lay 1.5-fold (0.17 log units) below the measured number; measured number inside the range.
By their numbers in this assay, from the lowest: compounds 3, 1 and 2 (each within the scatter of the next).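

Hydroxy in place of hydrogen on an aromatic carbon, meta to a hydroxy group, gives the first single-place step in the series: in this assay the change is a 1.2-fold lower number from compound 2 to compound 3 (0.07 log units; within the scatter), on a six-membered aromatic ring of carbon only. At this position, therefore, the step from hydrogen to hydroxy stays within the scatter, and compound 3 cannot be separated from compound 2. Nothing measured here gives a cause for this result.

The compounds shown leave open whether a methoxy, an amine or a carboxylic acid on the same aromatic carbon would also stay within the scatter. Also open, going by these compounds, is whether the same hydroxy would give a similar step on the core of compound 1, as a single step cannot establish a trend.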